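From a dihydroxyphenyl ketone to a carboxyphenyl ketone

The source may hold more compounds than are shown below. What is called first, only, known or untested is meant among the compounds shown, and "the series" means these compounds.

Of the compounds shown here, three have been measured. Compound 1 `O=C(/C(=C\c1ccc(O)c([N+](=O)[O-])c1)SCc1ccc(Br)cc1)c1ccc(O)cc1O` carries a 2,4-dihydroxyphenyl group on its carbonyl carbon. In a functional assay on DU-145 cells (Homo sapiens) for inhibition, read by trypan blue exclusion, with a stated time of 96 h (a higher number here means a weaker inhibitor of growth, a lower number a stronger inhibitor of growth), compound 1 reaches only a limit of the assay, > 100000 nM, and not a number (the limit of > 100000 nM in this assay, at which 1 of the 3 values shown sits). Compound 2 `COc1ccccc1/C=C(\C(=O)c1ccc(Br)cc1)S(=O)(=O)Cc1ccc(F)cc1` gives 25000 nM in this assay. Compound 3 `COc1ccc(/C=C(/SCc2ccc(F)cc2)C(=O)c2ccc(C(=O)O)cc2)cc1O` gives 10000 nM in this assay and carries the same 4-carboxyphenyl group on its carbonyl carbon that the new compound will carry.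

Compound 4 `O=C(O)c1ccc(C(=O)/C(=C\c2ccc(O)c([N+](=O)[O-])c2)SCc2ccc(Br)cc2)cc1` has not yet been measured. It differs from compound 1 in one place: 4-carboxyphenyl in place of 2,4-dihydroxyphenyl on a carbonyl carbon. For the measured compounds named here, no step between two measured compounds covers this exact change, so its size has to be judged from the values alone. Going by the values given here, the value of compound 3 is the only guide, and it points to a stronger inhibitor of growth. The step is therefore expected to run toward lower numbers, beyond the usual scatter: an at least 3.3-fold lower number from compound 1 to compound 4 (0.52 log units; beyond the scatter). For compound 4 the estimate in this assay is 30000 nM, within a range from 8000 nM to 120000 nM.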

Compound 4, concentration for 50% growth inhibition: 50000 nM
Compound 4: the middle estimate sits 1.7-fold (0.22 log units) below what was measured; the measured number falls inside the stated range.
By their numbers in this assay, from the lowest: compound 3; then compounds 2 and 4 (each within the scatter of the next). At a limit, above all of these: compound 1.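

At this place, on a carbonyl carbon whose other neighbour is a double-bonded chain carbon, 4-carboxyphenyl in place of 2,4-dihydroxyphenyl gives in this assay an at least 2.0-fold lower number from compound 1 to compound 4 (0.30 log units; that floor lies within the scatter). The value of compound 1, > 100000 nM, is a limit of the assay and not a number, and the step is only a floor: the limit of > 100000 nM in this assay, at which 1 of the 4 values shown sits. The earlier compounds shown here held no pair differing in one place, whereas compound 4 shows that the core of compound 1 can give a readable number in this assay with 4-carboxyphenyl on the carbonyl carbon.

What the compounds shown leave open is how a 4-hydroxyphenyl group or a 4-aminophenyl group would read at this place. On these data alone, the methyl ester of the 4-carboxyphenyl group remains equally open.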